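Oxolan-3-yl in place of cyclopentyl: a clearance estimate

The compounds below may be only part of what the source reports. "The series", "measured", "known", "first", "only" and "open" are said of these compounds alone.

Measured in an in vitro ADME assay on microsomes from liver (Homo sapiens) for pharmacokinetics; a lower number here means slower removal, a higher number faster removal of the compound:
- compound 1 `O=C(N[C@@H](CCN1C[C@@H]2CN(C(=O)c3cccc(F)c3)C[C@@H]2C1)c1cccc(F)c1)C1CCOC1` gives 331 mL.min-1.g-1
- compound 2 `O=C(N[C@@H](CCN1C[C@@H]2CN(C(=O)c3ccccn3)C[C@@H]2C1)c1cccc(F)c1)C1CCCC1` gives 512 mL.min-1.g-1

These two numbers lie within the usual scatter of each other, so compound 2 stands level with compound 1. Compound 3 `O=C(N[C@@H](CCN1C[C@@H]2CN(C(=O)c3ccccn3)C[C@@H]2C1)c1cccc(F)c1)C1CCOC1` matches compound 2 except for oxolan-3-yl in place of cyclopentyl on a carbonyl carbon. Within the data shown here, no measured pair shows this change alone. Compound 1 also carries oxolan-3-yl and gives 331 mL.min-1.g-1 in this assay, which offers weak support for expecting a modest move to a lower number. The expected change is a 2.1-fold lower number from compound 2 to compound 3 (0.33 log units; beyond the scatter) and would sit near the edge of the scatter. For compound 3 the estimated value is 240 mL.min-1.g-1 (range 110 mL.min-1.g-1 to 480 mL.min-1.g-1).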

Compound 3, intrinsic clearance in microsomes: 55 mL.min-1.g-1
The estimate for compound 3 lay 4.4-fold (0.64 log units) above the measured number; the measured number lies below the stated range.
By their numbers in this assay, from the lowest: compound 3; then compounds 1 and 2 (each within the scatter of the next).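

In this assay, among these compounds, oxolan-3-yl in place of cyclopentyl on a carbonyl carbon, as the only change, gives a 9.3-fold lower number from compound 2 to compound 3 (0.97 log units; beyond the scatter) and so shows that this position strongly affects the read-out. Pyridin-2-yl in place of 3-fluorophenyl on a carbonyl carbon, also as the only change, gives a 6.0-fold lower number from compound 1 to compound 3 (0.78 log units; beyond the scatter) and so shows that a second site matters too. No measurement here explains either step. As far as these compounds go, whether an oxan-4-yl ring or an amine such as pyrrolidin-3-yl on the same carbonyl carbon would give a similar number remains open. So does whether oxolan-3-yl has the same effect with groups other than pyridin-2-yl on the other side of the molecule.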